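The compounds below may be only part of what the source reports. "The series", "measured", "known", "first", "only" and "open" are said of these compounds alone.

Compound 1 `C/C=C/C(=O)N1CCCC(n2nc(-c3ccc(Oc4ccccc4)cc3)cc2C(=O)OCC)C1` gives 5100 nM in a functional assay on Rec1 cells (Homo sapiens) for inhibition, read by luminescence and CellTiter-Glo, with a stated time of 72 h; a higher number here means a weaker inhibitor, a lower number a stronger inhibitor. For the measured compounds named here, compound 2 `C=CC(=O)N1CCCC(n2nc(-c3ccc(Oc4ccccc4)cc3)cc2C(=O)OCC)C1` gives 13800 nM, the highest of the two numbers, and the single measured step is a 2.7-fold higher number from compound 1 to compound 2 (0.43 log units; beyond the scatter). Compound 3 `C=CC(=O)N1CCCC(n2nc(-c3ccc(Oc4ccccc4)cc3)cc2CO)C1` differs from compound 2 in one place: hydroxymethyl in place of ethoxycarbonyl on an aromatic carbon. Going by the values given here, that measured step concerns the vinyl group and says nothing about the ethoxycarbonyl group, so no measured step bears on this change, and its direction is open. Compound 3 is therefore expected near 12000 nM (range 2500 nM to 60000 nM). The expected step is a 1.2-fold lower number from compound 2 to compound 3 (0.06 log units; within the scatter), nothing beyond the scatter, with a wide range.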

Compound 3, half-maximal inhibitory concentration: 5400 nM
Estimate against measurement, compound 3: 2.2-fold (0.35 log units) above; low and high end bracket the measured number.
By their numbers in this assay, from the lowest: compounds 1 and 3 (each within the scatter of the next); then compound 2.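

In this assay, the aromatic carbon next to the ring nitrogen proves sensitive to its substituent: hydroxymethyl in place of ethoxycarbonyl gives a 2.6-fold lower number from compound 2 to compound 3 (0.41 log units; beyond the scatter). The ethoxycarbonyl group is therefore not required for the activity seen here, and a group of 2 heavy atoms in place of 5 does not weaken inhibition. No available evidence explains this step. Going by these compounds, whether a carboxylic acid or an aminomethyl group on this carbon would lower the number further remains open. Also open, on these data alone, is whether prop-1-en-1-yl in place of vinyl has the same effect alongside hydroxymethyl.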